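The source may report more compounds than this note shows. Statements on the series, on what has been measured and on what is new or still open speak of the compounds shown alone.

Compound 1 `CC(=O)Oc1ccccc1C(=O)O[C@H]1CO[C@H]2[C@@H]1OC[C@H]2OC(=O)c1ccccc1O`: 0.0825 h
Compound 2 `CC(=O)Oc1ccccc1C(=O)O[C@H]1CO[C@H]2[C@@H]1OC[C@H]2OC(=O)c1snnc1C`: 0.0642 h
Compound 3 `CC(=O)Oc1ccccc1C(=O)O[C@H]1CO[C@H]2[C@@H]1OC[C@H]2OC(=O)c1ccc(O)cc1`: 0.0198 h

In an ADME assay on a cell-free system (plasma, Homo sapiens) for metabolic stability, with Plasma (Rattus norvegicus) as the target, read by HPLC, at pH 7.4 (on this read-out higher numbers stand for a longer-lived compound and lower numbers for a shorter-lived compound), compound 3 has the lowest of the three numbers, standing a 4.2-fold lower number from compound 1 to compound 3 (0.62 log units; beyond the scatter) and a 3.2-fold lower number from compound 2 to compound 3 (0.51 log units; beyond the scatter). The shared core, an ester carrying an acetylated salicylate on one side, is the same in all three; only the group on the other carbonyl carbon changes.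

Compound 4 `CC(=O)Oc1ccccc1C(=O)O[C@H]1CO[C@H]2[C@@H]1OC[C@H]2OC(=O)c1ccccc1` keeps that core and differs from compound 3 by hydrogen in place of hydroxy on an aromatic carbon. Among the measured compounds shown here, no measured pair removes a hydroxy outright, so the two steps into compound 3 are the nearest guides: both replacements of the hydroxy-free or ortho-hydroxy ring by the 4-hydroxyphenyl ring shortened the half-life by a modest margin. Taking the hydroxy away again is therefore expected to move the number back toward compounds 1 and 2, as a 3.0-fold higher number from compound 3 to compound 4 (0.48 log units; beyond the scatter), rather than to leave it unchanged. Compound 4 is estimated at 0.06 h, within 0.02 h to 0.15 h.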

Compound 4, half-life: 0.055 h
Compound 4: the middle estimate sits 1.1-fold (0.04 log units) above what was measured; the measured number falls inside the stated range.
By their numbers in this assay, from the lowest: compound 3; then compounds 4, 2 and 1 (each within the scatter of the next).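

In this assay, taking the hydroxy off the ring gives a 2.8-fold higher number from compound 3 to compound 4 (0.44 log units; beyond the scatter), so the short half-life of compound 3 goes with that hydroxy and not with the phenyl ring that carries it. Compound 4 also stays level with its two neighbours, with a 1.2-fold lower number from compound 2 to compound 4 (0.07 log units; within the scatter) and a 1.5-fold lower number from compound 1 to compound 4 (0.18 log units; within the scatter), so the plain phenyl cannot be told apart from the thiadiazole group of compound 2, and the same exchange of hydroxy for hydrogen that counts in compound 3 leaves no readable change from compound 1. The data shown give no reason why the hydroxy counts in one compound and not in the other.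

Going by these compounds, it remains open whether a methoxy group, an amine or a carboxylic acid in the place of that hydroxy, para to the large group, would shorten the half-life as the hydroxy does. The acetylated salicylate side stays fixed throughout, so whether these steps hold with another group there is also unknown.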